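Fluorine to methyl on the cyclopropyl amide of a bicyclic diamine

This account rests on a few compounds, and the source may have more. Where it says the series, first, only, none or still open, it means among the compounds named here.

Measured compounds:
- compound 1, `O=C([C@@H]1C[C@@H]1F)N1CC2CC(C1)N2`, 120%
- compound 2, `O=C([C@@H]1C[C@H]1F)N1CC2CC(C1)N2`, 110%

In an assay on SH-EP1 cells for agonist activity at Neuronal acetylcholine receptor; alpha4/beta2 (Homo sapiens), read by FLIPR and calcium flux (on this read-out higher numbers stand for larger maximal responses and lower numbers for smaller maximal responses), compound 1 gives 120%, and compound 2 gives 110%. The pair differs only in how one stereocentre is drawn; the step of a number 10 percentage points lower from compound 1 to compound 2 (within the scatter) is within the scatter, and the difference between them may rest on (the fact that one of compounds 1 and 2 is drawn with a defined configuration and the other without, at the place where they differ). Compound 2 thus stands at the lower of the two numbers, yet not apart from compound 1 in any meaningful sense.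

Compound 3, `C[C@H]1C[C@@H]1C(=O)N1CC2CC(C1)N2`, is not yet measured. It differs from compound 2 by 2-methylcyclopropyl in place of 2-fluorocyclopropyl on a carbonyl carbon. Going by the values given here, no measured step touches this change; the only step known, from compound 1 to compound 2, lies within the scatter and concerns stereochemistry, not the substituent. Both measured compounds reach a maximal response at or above the reference, so compound 3 is expected to do the same, with the step of a number 5 percentage points lower from compound 2 to compound 3 (within the scatter) estimated to stay within the scatter. The value for compound 3 in this assay is therefore estimated at 105%, between 80% and 130%.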

Compound 3, largest response reached (Emax), in percent of the reference or control that the assay uses: 67%
Estimate against measurement, compound 3: 38 percentage points above; the whole stated range lies above it.
By their numbers in this assay, from the lowest: compound 3; then compounds 2 and 1 (each within the scatter of the next).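

In this assay the group on the carbonyl carbon matters far more than the drawn stereocentre did: 2-methylcyclopropyl in place of 2-fluorocyclopropyl brings a number 43 percentage points lower from compound 2 to compound 3 (beyond the scatter) and likewise a number 53 percentage points lower from compound 1 to compound 3 (beyond the scatter) as the comparison with the other fluorinated compound. The earlier step, a number 10 percentage points lower from compound 1 to compound 2 (within the scatter) and so no real separation, had shown nothing of the kind, whereas both new steps are large, so the maximal response at this place depends on which group is carried, even though the two groups have the same count of heavy atoms. Nothing in the data at hand speaks to why this exchange lowers the response.

The compounds shown leave open whether the other configurations of 2-methylcyclopropyl would give the same low response. They also leave open where a 2-chlorocyclopropyl, 2-ethylcyclopropyl or 2-hydroxymethylcyclopropyl amide would fall in this assay relative to these compounds.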